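A Ring Swap on the Sulfonyl Sulfur

The source may report more compounds than this note shows. Statements on the series, on what has been measured and on what is new or still open speak of the compounds shown alone.

In an ADME assay on HCT-116 cells (Homo sapiens) for cytotoxicity, read by CellTiter-Glo, with a stated time of 72 h (a higher number here means a weaker inhibitor, a lower number a stronger inhibitor), compound 1 `CC1CCN(C2CCN(S(=O)(=O)c3ccccc3Br)CC2)CC1` gives > 5000 nM, which is a limit of the assay and not a number. Compound 2 `CC1CCN(C2CCN(S(=O)(=O)c3nccn3C)CC2)CC1` gives > 10000 nM, which is also a limit. Going by the values given here, compound 2 therefore has no exact value of its own, and the one compound beside it has none either. Among the compounds with values here, the only measured comparison is a step that the two limits leave unreadable from compound 1 to compound 2.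

Compound 3 `CC1CCN(C2CCN(S(=O)(=O)c3ccc(Cl)nc3)CC2)CC1` keeps the shared core and carries 6-chloropyridin-3-yl in place of 1-methyl-1H-imidazol-2-yl on the sulfonyl sulfur: 6-chloropyridin-3-yl in place of 1-methyl-1H-imidazol-2-yl on a sulfonyl sulfur. Within the data shown here, no measured step of known size bears on this change, so the data offer no basis for predicting a shift in either direction. The best guide is compound 2 itself, whose reading of > 10000 nM is a limit. No shift beyond the usual scatter is therefore expected in this assay, and the expected step is an at least 1.1-fold lower number from compound 2 to compound 3 (0.04 log units; that floor lies within the scatter). Compound 3 is estimated at 9000 nM, with an expected range from 4000 nM to 25000 nM, and the assay may well report only a limit again.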

Compound 3, half-maximal inhibitory concentration: > 10000 nM
Compound 3: only a limit was reported; the forecaster's own chance of this, stated with the estimate: 80%; at least 1.1-fold (0.04 log units) between middle value and limit.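

In this assay compound 3 gives > 10000 nM as a limit of the assay and not a number. The steps from compound 1 to compound 3 and from compound 2 to compound 3 therefore cannot be read. The compounds shown leave open whether these three groups on the sulfonyl sulfur differ in this cytotoxicity read-out at all.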